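The source may hold more compounds than are shown below. What is called first, only, known or untested is meant among the compounds shown, and "the series" means these compounds.

Measured so far:
compound 1 `CN(C)CCn1cnnc1-c1cc(Oc2ccc(NC(=O)N/N=C/c3cccc(Cl)c3Cl)cc2F)ccn1` — 13200 nM
compound 2 `CN(C)CCn1cnnc1-c1cc(Oc2ccc(NC(=O)N/N=C/c3ccc(O)c(F)c3)cc2F)ccn1` — > 100000 nM

In a functional assay on U-87MG ATCC cells (Homo sapiens) for cytotoxicity, read by MTT assay, with a stated time of 72 h (on this read-out lower numbers stand for stronger inhibition and higher numbers for weaker inhibition), compound 1 gives 13200 nM. For compound 2 this assay returns only a limit, > 100000 nM, so compound 2 stands at the weak end of what the assay reports, as noted at the limit of > 100000 nM in this assay, at which 1 of the 2 values shown sits. Within the data shown here, the one measured step, an at least 7.5-fold higher number from compound 1 to compound 2 (0.87 log units; beyond the scatter), shows that swapping the aryl group on the carbon with a double bond to nitrogen moves the number well beyond the scatter.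

Compound 3 `Cc1cc(/C=N/NC(=O)Nc2ccc(Oc3ccnc(-c4nncn4CCN(C)C)c3)c(F)c2)cc(C)c1O` differs from compound 2 only at that carbon: 4-hydroxy-3,5-dimethylphenyl in place of 3-fluoro-4-hydroxyphenyl on a carbon with a double bond to nitrogen. Among the measured compounds shown here, no measured step covers this exact exchange; the step from compound 1 to compound 2 bears on it only in that the same site is varied, and there it cost a sizeable loss. The hydroxyphenyl motif is kept, so the expectation is that compound 3 stays weak in this assay, with a step of an at least 1.6-fold lower number from compound 2 to compound 3 (0.22 log units; that floor lies within the scatter) that is expected to be small or none beyond the scatter. Compound 3 is therefore estimated at 60000 nM, within 15000 nM to 200000 nM.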

Compound 3, half-maximal inhibitory concentration: 7710 nM
Estimate against measurement, compound 3: 7.8-fold (0.89 log units) above; measured number outside the range, below it.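

At the carbon with a double bond to nitrogen, keeping a hydroxyl-bearing ring does not by itself hold the series at the weak end of this assay: exchanging 3-fluoro-4-hydroxyphenyl for 4-hydroxy-3,5-dimethylphenyl gives an at least 12-fold lower number from compound 2 to compound 3 (1.11 log units; beyond the scatter). Compound 2 carries a limit and not a number, so the size of that step is only a floor: the limit of > 100000 nM in this assay, at which 1 of the 3 values shown sits. The two aryl groups of compound 1 and compound 3, though different in kind, are not told apart at this position, with a 1.7-fold lower number from compound 1 to compound 3 (0.23 log units; within the scatter), so among these three compounds the hydroxyl alone does not mark out the weak member, as compound 3 goes against any such reading.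

Open, going by these compounds, is which part of the exchange carries the step, the loss of the fluorine or the gain of the dimethyl substitution, and a ring with a single methyl group or a chlorine in its place would separate the two. Also open, on these data alone, is whether the hydroxyl of compound 3 contributes at all, which a methoxy group at the same place would test.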